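The compounds below may be only part of what the source reports. "The series", "measured", "known", "first", "only" and "open" are said of these compounds alone.

In a functional assay on THP-1 cells (Homo sapiens) for cytotoxicity, read by MTT assay, with a stated time of 24 h (a lower number here means a stronger inhibitor, a higher number a weaker inhibitor), compound 3 (`CN1C/C(=C\c2ccc(Br)cc2)C(=O)/C(=C/c2ccc(C#N)cc2)C1`) gives 4400 nM and lies within the scatter of compound 1 (`CN1C/C(=C\c2ccc(C(F)(F)F)cc2)C(=O)/C(=C/c2ccccc2F)C1`) with 5930 nM and of compound 2 (`CN1C/C(=C\c2ccc(Cl)cc2)C(=O)/C(=C/c2ccc(C#N)cc2)C1`) with 3180 nM on the same read-out. Compound 4 (`CN1C/C(=C\c2ccc(C#N)cc2)C(=O)/C(=C/c2ccc(C(F)(F)F)cc2)C1`) carries trifluoromethyl in place of bromo on an aromatic carbon when set against compound 3. Among the compounds with values here, the one measured step that bears on this is a 1.4-fold higher number from compound 2 to compound 3 (0.14 log units; within the scatter) for bromo in place of chloro on an aromatic carbon, and it stays within the scatter. Compound 1 also holds a trifluoromethyl and gives 5930 nM as its value. No step beyond the scatter is therefore expected in this assay for this change. The expected move is a 1.1-fold higher number from compound 3 to compound 4 (0.04 log units; within the scatter) and would stay within the scatter. For compound 4 the expected value is 4800 nM with 2400 nM to 9500 nM as the estimated range.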

Compound 4, half-maximal inhibitory concentration: 1430 nM
Beside the measured number, compound 4's estimate is 3.4-fold (0.53 log units) above it; the measured number lies below the stated range.
By their numbers in this assay, from the lowest: compound 4; then compounds 2, 3 and 1 (each within the scatter of the next).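

In this assay, trifluoromethyl on the aromatic carbon gives a 3.1-fold lower number from compound 3 to compound 4 (0.49 log units; beyond the scatter) and, set against chloro, a 2.2-fold lower number from compound 2 to compound 4 (0.35 log units; beyond the scatter), so this position responds to the group placed there, which the step between chloro and bromo, within the scatter, did not reveal. With trifluoromethyl in place on one side, 4-cyanophenyl in place of 2-fluorophenyl on the other gives a 4.1-fold lower number from compound 1 to compound 4 (0.62 log units; beyond the scatter), so that side counts as well. Nothing measured here accounts for these steps. Going by these compounds, whether an amine or a methoxy group on this aromatic carbon would go lower or higher stays open.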